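This account rests on a few compounds, and the source may have more. Where it says the series, first, only, none or still open, it means among the compounds named here.

Measured in a physicochemical assay for lipophilicity (on this read-out higher numbers stand for higher lipophilicity and lower numbers for lower lipophilicity), so far:

- compound 1 `CC/C=C(\CC)C(=O)O` gives 2.06
- compound 2 `CC/C=C(\CCC)C(=O)O` gives 2.59
- compound 3 `CC/C=C(\CCCC)C(=O)O` gives 3.11

Compound 1 is the lowest of these three, and the gaps to both others lie beyond the scatter. The next compound to be measured is compound 4 `C/C=C/C(=C\CC)C(=O)O`, which has prop-1-en-1-yl in place of ethyl on a double-bonded chain carbon bound to a carbonyl carbon and a double-bonded chain carbon. The counted difference is prop-1-en-1-yl in place of ethyl on a double-bonded chain carbon bound to a carbonyl carbon and a double-bonded chain carbon.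

Three measured steps offer some guidance. All of them extend a saturated chain. A methyl gives a number 0.53 log units higher from compound 1 to compound 2 (beyond the scatter) and another methyl gives a number 0.52 log units higher from compound 2 to compound 3 (beyond the scatter), while an ethyl gives a number 1.05 log units higher from compound 1 to compound 3 (beyond the scatter). The entering group in compound 4 is larger than the ethyl it replaces, which points upward. However, it also holds a double bond, and no measured step adds one or makes a change at this place. The size of the rise therefore remains uncertain, and the estimate is set somewhat short of the methyl steps, with a wide range.

The expected change is a number 0.34 log units higher from compound 1 to compound 4 (beyond the scatter) in this assay as an estimate. The estimated value for compound 4 is 2.4 with an expected range from 2.05 to 2.75.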

Compound 4, partition coefficient: 2.22
For compound 4 the middle estimate is 0.18 log units above the measured one; the range from low to high includes it.
By their numbers in this assay, from the lowest: compounds 1 and 4 (each within the scatter of the next); then compound 2; then compound 3.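

In this assay, putting prop-1-en-1-yl in place of ethyl on a double-bonded chain carbon bound to a carbonyl carbon and a double-bonded chain carbon gives a number 0.16 log units higher from compound 1 to compound 4 (within the scatter) and so leaves compounds 1 and 4 indistinguishable on this read-out. The saturated chain extensions seen earlier all gave steps beyond the scatter, so a larger group at this place does not by itself bring a clear rise. Comparing the same entering group with propyl gives a number 0.37 log units lower from compound 2 to compound 4 (beyond the scatter) and shows that this read-out separates these two groups of similar length, although nothing available explains that gap.

The compounds shown leave open whether the pattern extends to a longer unsaturated chain such as but-1-en-1-yl, or to a triple-bonded group such as prop-1-yn-1-yl. They also leave open how a cyclopropyl group or a chain ending in a hydroxyl group would compare at this same place on the shared core.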